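Notes on a sulfo ester variant in the series

The source may hold more compounds than are shown below. What is called first, only, known or untested is meant among the compounds shown, and "the series" means these compounds.

In a functional assay on MCF7 cells (Homo sapiens) for inhibition, read by MTT assay, with a stated time of 3 days; on this read-out lower numbers stand for stronger inhibition and higher numbers for weaker inhibition:
- compound 1 `CC[C@H](C)[C@H](NCC(=O)NNC(=O)COc1ccc(-c2nc3ccccc3s2)cc1OC)C(=O)O`: 1710 nM
- compound 2 `CCOC(=O)CN(C)CC(=O)NNC(=O)COc1ccc(-c2nc3ccccc3s2)cc1OC`: 1980 nM

Compound 2 stands within the scatter of compound 1, so these two numbers do not separate. Compound 3 `CCOC(=O)[C@H](CS(=O)(=O)O)NCC(=O)NNC(=O)COc1ccc(-c2nc3ccccc3s2)cc1OC` changes the group on a saturated chain carbon bound to a carbonyl carbon: (1-(ethoxycarbonyl)-2-sulfoethyl)amino in place of ((ethoxycarbonyl)methyl)(methyl)amino on a saturated chain carbon bound to a carbonyl carbon. Among the compounds with values here, the only measured step at this place, a 1.2-fold higher number from compound 1 to compound 2 (0.06 log units; within the scatter), lies within the scatter. Within the data shown here, no measured compound carries the sulfo group, so that step is a loose guide and the range is kept wide. No step beyond the scatter is expected in this assay. The expected change is a 1.2-fold higher number from compound 2 to compound 3 (0.07 log units; within the scatter). For compound 3 the estimated value is 2300 nM, with an expected range of 900 nM to 6500 nM.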

Compound 3, half-maximal inhibitory concentration: 1990 nM
Compound 3: middle estimate off by 1.2-fold (0.06 log units), on the high side, within the range that was stated.
By their numbers in this assay, from the lowest: compounds 1, 2 and 3 (each within the scatter of the next).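

In this assay the sulfo-bearing group gives a 1.0-fold higher number from compound 2 to compound 3 (0.00 log units; within the scatter) and, against the branched acid, a 1.2-fold higher number from compound 1 to compound 3 (0.07 log units; within the scatter). All three groups on this saturated chain carbon bound to a carbonyl carbon therefore remain within the scatter of one another, now including a group with a sulfo substituent and a defined stereocentre. Nothing available accounts for this lack of separation. On these data alone, it remains open whether a plain primary amine at this place, or a longer chain carrying the sulfo group, would give a step beyond the scatter.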